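The source may hold more compounds than are shown below. What is called first, only, known or untested is meant among the compounds shown, and "the series" means these compounds.

The measured compounds are:

compound 1, `CC(C(=O)NCc1ccc(C(F)(F)F)cc1N1CCC(c2ccc(F)cc2)CC1)c1ccc(NS(C)(=O)=O)c(F)c1`, 0.9 nM
compound 2, `Cc1ccc(N2CCN(c3cc(C(F)(F)F)ccc3CNC(=O)C(C)c3ccc(NS(C)(=O)=O)c(F)c3)CC2)cc1`, 0.7 nM
compound 3, `CC(C(=O)NCc1ccc(C(F)(F)F)cc1OCc1ccccc1)c1ccc(NS(C)(=O)=O)c(F)c1`, 0.9 nM

All three were tested in an assay on CHO cells for antagonist activity at transient receptor potential cation channel subfamily V member 1 (Homo sapiens), read by FLIPR; a higher number here means a weaker inhibitor, a lower number a stronger inhibitor. Among the compounds with values here, compound 3 stands level with compound 1 at the digits reported, and together these two have the highest numbers of the three; compound 2 is the one furthest from compound 3, yet the gap between them is within the usual scatter of repeated measurements, so nothing separates the three on this read-out. Compounds 1 and 2 carry a cyclic amine on the shared core where compound 3 carries its benzyloxy group, and all three land in the same narrow band of inhibition constants.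

The compound that follows is compound 4, `CC(C(=O)NCc1ccc(C(F)(F)F)cc1-c1cccc(Cl)c1)c1ccc(NS(C)(=O)=O)c(F)c1`. Its difference from compound 3 is 3-chlorophenyl in place of benzyloxy on an aromatic carbon. Within the data shown here, no measured pair shows this particular change, so the direction of the step has to be inferred from the fact that three rather different groups at this aromatic carbon all give closely similar numbers in this assay. On that basis a small step toward a higher number is expected, of a size at or near the edge of the scatter, as a 2.2-fold higher number from compound 3 to compound 4 (0.35 log units; beyond the scatter). Compound 4 is therefore estimated at 2 nM, with a range from 0.5 nM to 10 nM.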

Compound 4, inhibition constant: 1 nM
Beside the measured number, compound 4's estimate is 2.0-fold (0.30 log units) above it; low and high end bracket the measured number.
By their numbers in this assay, from the lowest: compounds 2, 1, 3 and 4 (each within the scatter of the next).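

Within the data shown here, exchanging benzyloxy for 3-chlorophenyl in this assay gives a 1.1-fold higher number from compound 3 to compound 4 (0.05 log units; within the scatter) and provides the only pair here that isolates a single change on this aromatic carbon, ortho to a large group and meta to a trifluoromethyl group. The change removes the oxygen of benzyloxy, the only hydrogen-bond acceptor in either group, and brings in a chlorine, yet the step stays within the scatter, so this position accepts either group with no measurable separation on this read-out. No measurement at hand explains why the two groups read alike.

The compounds shown leave open whether the same holds for groups without an aromatic ring at this carbon, such as a methoxy group, a short alkyl chain, a primary amine or a carboxylic acid, any of which would test whether a ring is needed here at all. They also leave open whether the chlorine matters or where it sits, since neither plain phenyl nor 4-chlorophenyl appears among them.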